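The source may report more compounds than this note shows. Statements on the series, on what has been measured and on what is new or still open speak of the compounds shown alone.

In a functional assay on HepG2 cells (Homo sapiens) for cytotoxicity, read by MTT assay, with a stated time of 24 h (on this read-out higher numbers stand for weaker inhibition and lower numbers for stronger inhibition), compound 3 `O=C1/C(=C/c2ccncc2)CN(S(=O)(=O)c2ccccc2)C/C1=C\c1ccccc1C(F)(F)F` gives 7020 nM and lies within the scatter of compound 2 `O=C1/C(=C/c2ccncc2)CNC/C1=C\c1ccccc1C(F)(F)F` at 6130 nM while compound 1 `O=C1/C(=C/c2cccnc2)CN(S(=O)(=O)c2ccc(F)cc2)C/C1=C\c1ccccc1C(F)(F)F` at 2340 nM shows a lower number beyond the scatter. Compound 4 `O=C1/C(=C/c2ccncc2)CN(S(=O)(=O)c2ccc(F)cc2)C/C1=C\c1ccccc1C(F)(F)F` differs from compound 3 by fluoro in place of hydrogen on an aromatic carbon, para to a large group fluoro in place of hydrogen on an aromatic carbon and so carries (4-fluorophenyl)sulfonyl instead of phenylsulfonyl. Among the measured compounds shown here, the one measured step at this nitrogen substituent is a 1.1-fold higher number from compound 2 to compound 3 (0.06 log units; within the scatter) for phenylsulfonyl in place of hydrogen, and it stays within the scatter. For the measured compounds named here, no measured pair isolates the fluoro change. Compound 1 at 2340 nM already holds the (4-fluorophenyl)sulfonyl group but also differs from compound 4 elsewhere in the structure, so it offers only a weak hint towards lower numbers. In this assay the expected change is therefore small and probably not beyond the scatter. The estimated step is a 1.4-fold lower number from compound 3 to compound 4 (0.15 log units; within the scatter) and points to a slightly lower number. For compound 4 the expected value is 5000 nM (estimated range 2200 nM to 10000 nM).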

Compound 4, half-maximal inhibitory concentration: 4010 nM
Estimate against measurement, compound 4: 1.2-fold (0.10 log units) above, and the stated range covers the measured number.
By their numbers in this assay, from the lowest: compounds 1, 4, 2 and 3 (each within the scatter of the next, the first and the last beyond it).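

In this assay, among the compounds shown here, phenyl to 4-fluorophenyl now has its own measured step, a 1.8-fold lower number from compound 3 to compound 4 (0.24 log units; within the scatter), so this change taken alone stays within the scatter. (4-Fluorophenyl)sulfonyl in place of hydrogen on the amine nitrogen gives a 1.5-fold lower number from compound 2 to compound 4 (0.18 log units; within the scatter), so neither sulfonyl group read at this nitrogen separates from the hydrogen of compound 2, and pyridin-4-yl in place of pyridin-3-yl, read here for the first time, gives a 1.7-fold higher number from compound 1 to compound 4 (0.23 log units; within the scatter), again within the scatter. Nothing measured on these compounds accounts for any of these steps. From the compounds shown here alone, whether an acetyl group or a longer alkyl chain on the same nitrogen, or a chloro or methoxy group in place of the fluoro, would move the number beyond the scatter remains open. Going by these compounds, the effect of pyridin-2-yl at the same chain carbon also remains open.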